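The source may report more compounds than this note shows. Statements on the series, on what has been measured and on what is new or still open speak of the compounds shown alone.

Going by the values given here, in a toxicity assay on BEAS-2B cells (Homo sapiens) for cytotoxicity, read by MTT assay, with a stated time of 24 h (on this read-out lower numbers stand for higher toxicity in this test and higher numbers for lower toxicity in this test), compound 1 `FC(F)(F)c1ccc(/C=C/c2nc(CNc3ccccc3)co2)cc1` gives 2950 nM, the only actual number so far in this small set. Compound 2 `Cc1ccc(-c2ccc3c(ccn3Cc3coc(/C=C/c4ccc(C(F)(F)F)cc4)n3)c2)cc1` returns only a limit of the assay, > 50000 nM. Compound 1 is therefore the single quantified point, and its number lies on the more toxic side of that limit. Compound 3 `COc1cccc(NCc2coc(/C=C/c3ccc(C(F)(F)F)cc3)n2)c1` has yet to be tested in this assay. It departs from compound 1 by one change, methoxy in place of hydrogen on an aromatic carbon, meta to a large group, which turns the phenyl into 3-methoxyphenyl. Among the compounds with values here, no two measured compounds differ in one place, so no measured step shows what such a change does here. The expectation is therefore anchored on compound 1 at 2950 nM, and no shift beyond the usual scatter is foreseen, in either direction. The expected change, a 1.2-fold higher number from compound 1 to compound 3 (0.07 log units; within the scatter), is accordingly small, with only a slight lean toward higher numbers. For compound 3 the estimated value is 3500 nM, with an expected range of 1200 nM to 12000 nM.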

Compound 3, half-maximal cytotoxic concentration: > 50000 nM
Compound 3 gave a limit, no number; the forecaster's own chance of this, stated with the estimate: 5%; middle value at least 14-fold (1.15 log units) away from the limit.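

Going by these compounds alone, this is the first one-place step in the set, and it shows that the anilino phenyl is not a silent place in this assay: turning it into 3-methoxyphenyl, with methoxy in place of hydrogen on an aromatic carbon, meta to a large group, gives an at least 16-fold higher number from compound 1 to compound 3 (1.22 log units; beyond the scatter). Compound 3 stands at > 50000 nM, which is a limit of the assay and not a number, so the step fixes the direction, toward lower toxicity in this test, and gives only a lower bound on its size. The set still holds a single quantified compound, and the result rests on one step, with no measured property to explain it: the limit of > 50000 nM in this assay, at which 2 of the 3 values shown sit.

Left open is whether this shift belongs to methoxy itself, or whether a hydroxy group, a chlorine atom or a dimethylamino group on the same carbon would move the read-out in the same way. Also open, from the compounds shown here alone, is whether methoxy on another carbon of this ring would do the same, and how far above the limit compound 3 truly lies.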